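Sulfonamide aryl swap in the arylketone piperidine series

The compounds below may be only part of what the source reports. "The series", "measured", "known", "first", "only" and "open" are said of these compounds alone.

Measured so far:
- compound 1 `COc1ccc(S(=O)(=O)NCCN2CCC(CCC(=O)c3cc(Cl)c(N)cc3OC)CC2)cc1Br`: 72%
- compound 2 `COc1ccc(S(=O)(=O)CCCN2CCC(CCC(=O)c3cc(Cl)c(N)cc3OC)CC2)cc1`: 33%

Two compounds of the shared core carry a number in an assay on HEK293 cells for displacement of a labelled ligand from 5-hydroxytryptamine receptor 6 (Homo sapiens), with a stated time of 60 min, tested at 1 uM, in the presence of a further agent that is not named here; on this read-out higher numbers stand for a stronger effect at the one concentration tested and lower numbers for a weaker effect. Compound 1 gives 72% and stands highest of the two; compound 2 gives 33%, which lies below compound 1 by a gap beyond the scatter. For the measured compounds named here, the two differ in more than one place, so no single step is read from them.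

Compound 3 `COc1cc(N)c(Cl)cc1C(=O)CCC1CCN(CCNS(=O)(=O)c2cc(Br)c(N)c(Br)c2)CC1` is not yet measured. Against compound 1 it differs on the sulfonyl sulfur, whose other neighbour is the sulfonamide nitrogen: 4-amino-3,5-dibromophenyl in place of 3-bromo-4-methoxyphenyl on a sulfonyl sulfur. The core, the linker and the ketone side of the molecule are unchanged.

Going by the values given here, no step between measured compounds covers this kind of change, so the expectation rests on compound 1 alone with its value of 72%. A small step in this assay, downward or none beyond the scatter, is expected, a number 9 percentage points lower from compound 1 to compound 3 (within the scatter). For compound 3 the estimate is 63%, with a range from 40% to 82%.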

Compound 3, a percentage reported as inhibition, at one concentration (the size of the read-out at that concentration, not a potency): 83%
Beside the measured number, compound 3's estimate is 20 percentage points below it; measured number outside the range, above it.
By their numbers in this assay, from the lowest: compound 2; then compound 1; then compound 3.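

In this assay, the sulfonyl sulfur whose other neighbour is the sulfonamide nitrogen accepts 4-amino-3,5-dibromophenyl in place of 3-bromo-4-methoxyphenyl, with a number 11 percentage points higher from compound 1 to compound 3 (beyond the scatter). For the compounds shown here, this is the first change in a single place, and it shows that the aryl group on this sulfur can move the read-out at the one concentration tested, though only modestly. The heavy-atom count stays at 9 while the entering group has 1 hydrogen-bond donor and 2 bromine where the leaving group has 0 hydrogen-bond donors and 1 bromine, and no measurement bearing on the origin of the step is available to explain it.

The swap changes several features at once, so this single step cannot assign the gain to the amino group or to the second bromine; 4-amino-3-bromophenyl and 3,5-dibromo-4-methoxyphenyl would separate the two. Also open, on these data alone, is whether 4-amino-3,5-dibromophenyl gives a similar step on the sulfone chain of compound 2, and how an unsubstituted phenyl or a 4-amino-3,5-dichlorophenyl would read at this position.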